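Aryl group swap on the carbonyl: compound 3 to compound 4

This account rests on a few compounds, and the source may have more. Where it says the series, first, only, none or still open, it means among the compounds named here.

Measured in a functional assay on C8166 cells (Homo sapiens) for cytotoxicity, read by MTT assay; a lower number here means that less compound is tolerated, a higher number that more compound is tolerated:
- compound 1 `Cc1cc(S(N)(=O)=O)ccc1NC(=O)COc1ccc(Cl)cc1NC(=O)c1cccc(Cl)c1`: 59700 nM
- compound 2 `Cc1cc(S(N)(=O)=O)ccc1NC(=O)COc1ccc(Cl)cc1NC(=O)c1cccc([N+](=O)[O-])c1`: 58800 nM
- compound 3 `Cc1ccc(C)c(C(=O)Nc2cc(Cl)ccc2OCC(=O)Nc2ccc(S(N)(=O)=O)cc2C)c1`: 79700 nM

Not yet measured: compound 4 `Cc1cc(S(N)(=O)=O)ccc1NC(=O)COc1ccc(Cl)cc1NC(=O)c1ccc(Cl)cc1Cl`.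

In this assay, compound 3 gives 79700 nM, the highest of the three numbers, but it cannot be separated from the other two. The next structural change keeps the shared core and puts 2,4-dichlorophenyl in place of 2,5-dimethylphenyl on a carbonyl carbon.

Two measured steps change the group at this same place: a 1.3-fold higher number from compound 1 to compound 3 (0.13 log units; within the scatter) and a 1.4-fold higher number from compound 2 to compound 3 (0.13 log units; within the scatter). Both lie within the scatter, as does a 1.0-fold lower number from compound 1 to compound 2 (0.01 log units; within the scatter). Within the data shown here, no compound with 2,4-dichlorophenyl has been measured yet. Compound 1, with 3-chlorophenyl at this place, gives 59700 nM, so the estimate is set close to that value.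

The expected change is a 1.3-fold lower number from compound 3 to compound 4 (0.11 log units; within the scatter), which would not go beyond the scatter. For compound 4 the estimated value is 62000 nM, with an expected range from 36000 nM to 105000 nM.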

Compound 4, half-maximal cytotoxic concentration: 61100 nM
The estimate for compound 4 lay 1.0-fold (0.01 log units) above the measured number, and the stated range covers the measured number.
By their numbers in this assay, from the lowest: compounds 2, 1, 4 and 3 (each within the scatter of the next).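

In this assay the 2,4-dichlorophenyl group on a carbonyl carbon cannot be separated from any of the three other aryl groups at this place (a 1.3-fold lower number from compound 3 to compound 4 (0.12 log units; within the scatter); a 1.0-fold higher number from compound 2 to compound 4 (0.02 log units; within the scatter); a 1.0-fold higher number from compound 1 to compound 4 (0.01 log units; within the scatter)). Among these compounds, the result adds a fourth aryl group to this flat set: two chlorines on the ring read the same as the single chlorine of compound 1, the nitro group of compound 2 and the two methyl groups of compound 3. No measured data bear on why these four numbers stay together.

From the compounds shown here alone, all four compounds carry a substituted phenyl group at this place, so it remains open whether a carboxylic acid, an aliphatic amine or a longer alkyl chain there would move the number beyond the scatter. Changes elsewhere on the shared core also remain open.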